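A few compounds are considered here, and "the series" means these few. Any claim that something is new, unique, unknown or untested is made for them only; others in the source may bear on it.

Compound 1 `CC(C)CNc1ccc(NC(=O)c2cc(Cl)ccc2O)c(Cl)c1` shares its core with compound 2 `CCCCCCCCC(C)Nc1ccc(NC(=O)c2cc(Cl)ccc2O)c(Cl)c1` and compound 3 `O=C(Nc1ccc(NCc2cc(C(F)(F)F)cc(C(F)(F)F)c2)cc1Cl)c1cc(Cl)ccc1O`. In an ADME assay on A549 cells (Homo sapiens) for cytotoxicity, read by resazurin assay, with a stated time of 48 h (a lower number here means that less compound is tolerated, a higher number that more compound is tolerated), compound 1 gives 60000 nM, the second highest of the three numbers. Compound 3 gives 92800 nM, a value within the scatter of that of compound 1. Compound 2 gives 21900 nM, a lower number beyond the scatter, so compound 2 is tolerated less than compound 1. Compound 4 `O=C(Nc1ccc(NCc2ccc3cn[nH]c3c2)cc1Cl)c1cc(Cl)ccc1O` is still to be measured in this assay. It differs from compound 1 by 1H-indazol-6-yl in place of isopropyl on a saturated chain carbon bound to a nitrogen on an aromatic ring. Going by the values given here, no pair of measured compounds isolates a change of this kind, so there is no step to lean on. Compound 4 is expected to stay close to compound 1, with a 1.1-fold higher number from compound 1 to compound 4 (0.03 log units; within the scatter) a step not beyond the scatter. Compound 4 is estimated at 65000 nM, within 30000 nM to 140000 nM.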

Compound 4, half-maximal cytotoxic concentration: 45300 nM
Compound 4: the middle estimate sits 1.4-fold (0.16 log units) above what was measured; measured number inside the range.
By their numbers in this assay, from the lowest: compound 2; then compounds 4, 1 and 3 (each within the scatter of the next, the first and the last beyond it).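

Replacing isopropyl with 1H-indazol-6-yl on a saturated chain carbon bound to a nitrogen on an aromatic ring gives, in this assay, a 1.3-fold lower number from compound 1 to compound 4 (0.12 log units; within the scatter). The earlier compounds shown here offered no such single-change pair; this one shows that a much larger, two-ring aromatic group bearing a hydrogen-bond donor and acceptor leaves the number indistinguishable from that of the small isopropyl group. No measurement here offers a reason for this. As far as these compounds go, whether a carboxylic acid or an amine at this place would leave the number equally unchanged remains open.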